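This account rests on a few compounds, and the source may have more. Where it says the series, first, only, none or still open, it means among the compounds named here.

Measured so far in a functional assay (Platelet, plasma) for inhibition, with Homo sapiens as the target; a lower number here means a stronger inhibitor, a higher number a weaker inhibitor:
compound 1 `CC1(C(=O)NS(=O)(=O)Cc2ccc(F)cc2)CCN(c2nc3c(cc2C#N)C(=O)OC3)CC1`: 35400 nM
compound 2 `N#Cc1cc2c(nc1N1CCC(C(=O)NS(=O)(=O)Cc3ccc(F)cc3F)CC1)COC2=O`: 5200 nM
compound 3 `CC1(C(=O)NS(=O)(=O)Cc2ccccc2)CCN(c2nc3c(cc2C#N)C(=O)OC3)CC1`: 6680 nM

Compound 3 lies within the scatter of compound 2 and well under compound 1. Compound 4 `CC1(C(=O)NS(=O)(=O)Cc2ccc(F)cc2F)CCN(c2nc3c(cc2C#N)C(=O)OC3)CC1` differs from compound 3 as follows: 2,4-difluorophenyl in place of phenyl on a saturated chain carbon bound to a sulfonyl sulfur, with 2,4-difluorophenyl in place of phenyl on a saturated chain carbon bound to a sulfonyl sulfur. Going by the values given here, the one measured step that bears on this is a 5.3-fold lower number from compound 1 to compound 3 (0.72 log units; beyond the scatter), a modest one, with hydrogen in place of fluoro on an aromatic carbon. Read in reverse, it points to a higher number for compound 4. Compound 2, which also carries 2,4-difluorobenzyl, gives 5200 nM, so a somewhat smaller rise is expected. The expected step is a 2.2-fold higher number from compound 3 to compound 4 (0.35 log units; beyond the scatter). For compound 4 the estimated value is 15000 nM, with an expected range from 5000 nM to 40000 nM.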

Compound 4, half-maximal inhibitory concentration: 8760 nM
Estimate against measurement, compound 4: 1.7-fold (0.23 log units) above; the range from low to high includes it.
By their numbers in this assay, from the lowest: compounds 2, 3 and 4 (each within the scatter of the next); then compound 1.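

In this assay, going by these compounds alone, going from phenyl to 2,4-difluorophenyl gives a 1.3-fold higher number from compound 3 to compound 4 (0.12 log units; within the scatter), while the added fluoro on the aromatic carbon gives a 4.0-fold lower number from compound 1 to compound 4 (0.61 log units; beyond the scatter), so the rise seen with the single fluoro of compound 1 does not carry over to compound 4. The methyl on the saturated ring carbon also makes little difference with 2,4-difluorobenzyl in place, at a 1.7-fold higher number from compound 2 to compound 4 (0.23 log units; within the scatter). Nothing shown here accounts for these results. Going by these compounds, it remains open how chloro or methoxy would compare with fluoro on the phenyl ring, and how ethyl would compare with methyl on the saturated ring carbon.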